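Replacing 3-cyanophenyl with 2-chlorophenyl in compound 1

The source may hold more compounds than are shown below. What is called first, only, known or untested is meant among the compounds shown, and "the series" means these compounds.

In a functional assay on U-373MG ATCC cells (Homo sapiens) for inhibition, read by MTT assay, with a stated time of 72 h (on this read-out higher numbers stand for weaker inhibition and lower numbers for stronger inhibition), compound 1 `CC1(C)CC(NC(=S)Nc2cccc(C#N)c2)c2cc(Br)ccc2O1` gives 6000 nM. Two close relatives differ from it only in one group on an aromatic carbon: compound 3 `CC1(C)CC(NC(=S)Nc2cccc(C#N)c2)c2cc(Cl)ccc2O1` gives 7000 nM, and compound 2 `CC1(C)CC(NC(=S)Nc2cccc(C#N)c2)c2cc(F)ccc2O1` gives 30000 nM. With chloro in place of bromo, the step is small and within the scatter: a 1.2-fold higher number from compound 1 to compound 3 (0.07 log units; within the scatter). With fluoro in place of bromo, it is larger: a 5.0-fold higher number from compound 1 to compound 2 (0.70 log units; beyond the scatter). Compound 1 therefore stands level with compound 3, and both sit at the stronger end of this small set.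

Compound 4 `CC1(C)CC(NC(=S)Nc2ccccc2Cl)c2cc(Br)ccc2O1` keeps the bromo and changes a different place: 2-chlorophenyl in place of 3-cyanophenyl on an amide-type nitrogen. In words, 2-chlorophenyl replaces 3-cyanophenyl on an amide-type nitrogen. Going by the values given here, no measured step touches this place, so the data give no direct guide to its size or direction. Among the compounds with values here, the only indirect guide is the fluoro change on compound 1, where a 5.0-fold higher number from compound 1 to compound 2 (0.70 log units; beyond the scatter) shows that a single change can matter. The estimated result is no clear shift beyond the scatter: a 1.3-fold higher number from compound 1 to compound 4 (0.12 log units; within the scatter). For compound 4, the expected value is 8000 nM, with an estimated range of 2500 nM to 25000 nM.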

Compound 4, half-maximal inhibitory concentration: 34000 nM
The estimate for compound 4 lay 4.3-fold (0.63 log units) below the measured number; measured number outside the range, above it.
By their numbers in this assay, from the lowest: compounds 1 and 3 (each within the scatter of the next); then compounds 2 and 4 (each within the scatter of the next).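

Going by these compounds alone, until this result, only the halogen on the shared core had changed. Within the data shown here, compound 4 gives the first reading at the amide-type nitrogen, and in this assay the swap to 2-chlorophenyl gives a 5.7-fold higher number from compound 1 to compound 4 (0.75 log units; beyond the scatter), so this place also affects the read-out, and keeping the bromo does not hold the number level with compound 1. No measurement shown here offers an explanation for this step.

The swap removes 3-cyanophenyl and brings in 2-chlorophenyl in one move, so these compounds cannot separate the loss of the nitrile from the arrival of the chloro group. Plain phenyl on this nitrogen, or a phenyl ring carrying an amine or a carboxylic acid, would show how the read-out responds to other groups here.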